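The compounds below may be only part of what the source reports. "The series", "measured", "known", "first", "only" and "open" are said of these compounds alone.

Measured so far in an assay for inhibition of Indoleamine 2,3-dioxygenase 1 (Homo sapiens), with stated times of 10 min and 60 min, tested at 100 uM; on this read-out higher numbers stand for a stronger effect at the one concentration tested and lower numbers for a weaker effect:
compound 1 `O=[N+]([O-])c1cccc(CNc2cc(Br)cc3[nH]ncc23)c1`: 95%
compound 2 `O=[N+]([O-])c1cccc(CNc2cc(C(F)(F)F)cc3[nH]ncc23)c1`: 69%
compound 3 `O=[N+]([O-])c1ccc(CNc2cc(Br)cc3[nH]ncc23)cc1`: 87%

Compound 1 and compound 2 differ in one place, (trifluoromethyl in place of bromo on an aromatic carbon), and the step seen in this assay is a number 26 percentage points lower from compound 1 to compound 2 (beyond the scatter). Compound 3 has the same atoms as compound 1 joined differently; the difference between the two cores is not broken down here. In this assay compound 3 gives 87%, within the scatter of compound 1 and beyond it relative to compound 2.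

Compound 4 `O=[N+]([O-])c1ccc(CNc2cc(C(F)(F)F)cc3[nH]ncc23)cc1` has not yet been measured. It differs from compound 3 by trifluoromethyl in place of bromo on an aromatic carbon, the same change that separates compound 1 from compound 2, made twice among these compounds. Because a number 26 percentage points lower from compound 1 to compound 2 (beyond the scatter) accompanied this change once, a step of similar size is expected in this assay, a number 26 percentage points lower from compound 3 to compound 4 (beyond the scatter). Compound 4 is therefore expected to give about 61%, likely between 45% and 76%.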

Compound 4, a percentage reported as inhibition, at one concentration (the size of the read-out at that concentration, not a potency): 61%
For compound 4 middle estimate and measured number coincide at the digits printed, within the range that was stated.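

In this assay, trifluoromethyl in place of bromo on an aromatic carbon gave a number 26 percentage points lower from compound 3 to compound 4 (beyond the scatter). Set beside the earlier step, the change carried over from one core to the other with no visible difference in size: the same change on two cores in this assay, a number 26 percentage points lower (beyond the scatter) from compound 1 to compound 2 and a number 26 percentage points lower (beyond the scatter) from compound 3 to compound 4, 0 percentage points apart, within the scatter of two such steps. Among these compounds, this shows that the step held on these two cores, but it rests on only two pairs read at a single concentration, so it neither measures potency nor explains the step, and it does not establish that the step would hold on any further core.

The compounds shown leave open how other groups on that aromatic carbon, such as a nitrile or a carboxylic acid, would read. They also leave open what an amine in place of the nitro group would do.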